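Cyclooctyl in place of cyclobutyl on the amide nitrogen

The source may report more compounds than this note shows. Statements on the series, on what has been measured and on what is new or still open speak of the compounds shown alone.

Compound 1 `CC1CCCCC1N(CCCCCCN1C[C@H](O)[C@@H](O)[C@H](O)[C@H]1CO)C(=O)C(C)(C)C`: in an ADME assay on BHK cells (Mesocricetus auratus) for cytotoxicity, read by MTT assay (on this read-out higher numbers stand for lower toxicity in this test and lower numbers for higher toxicity in this test), compound 1 gives > 500000 nM, which is a limit of the assay and not a number.
Compound 2 `CC(C)(C)C(=O)N(CCCCCCN1C[C@H](O)[C@@H](O)[C@H](O)[C@H]1CO)C1CC1`: in this assay compound 2 gives > 500000 nM, again a limit.
Compound 3 `CC(C)(C)C(=O)N(CCCCCCN1C[C@H](O)[C@@H](O)[C@H](O)[C@H]1CO)C1CCC1`: in this assay compound 3 gives > 500000 nM, also a limit.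

Compound 3 therefore stands at the same limit as every other measured compound; no value in this set is a number, and all sit at the limit of > 500000 nM in this assay, at which 3 of the 3 values shown sit. The steps among them, a step that the two limits leave unreadable from compound 1 to compound 2, a step that the two limits leave unreadable from compound 1 to compound 3 and a step that the two limits leave unreadable from compound 2 to compound 3, are accordingly unreadable in size, and nothing in them separates the cyclohexyl, cyclopropyl and cyclobutyl groups on the amide-type nitrogen.

Compound 4 `CC(C)(C)C(=O)N(CCCCCCN1C[C@H](O)[C@@H](O)[C@H](O)[C@H]1CO)C1CCCCCCC1` differs from compound 3 by cyclooctyl in place of cyclobutyl on an amide-type nitrogen. The measured steps that bear on this change are the ring swaps on the same nitrogen, all of which stayed at the limit; none of them shows a step beyond the scatter, and no reading exists for a ring of this size. Compound 4 is therefore expected to sit at the limit as well, with a number no higher from compound 3 to compound 4 (the limit leaves the size open) as the expected step. The estimate for compound 4 in this assay is 500000 nM, within 200000 nM to 2000000 nM.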

Compound 4, half-maximal cytotoxic concentration: 208000 nM
Compound 4: middle estimate off by 2.4-fold (0.38 log units), on the high side; the range from low to high includes it.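

In this assay, among the compounds shown here, cyclooctyl on the amide-type nitrogen gives the first steps in this set that can be read: an at least 2.4-fold lower number from compound 3 to compound 4 (0.38 log units; beyond the scatter), an at least 2.4-fold lower number from compound 2 to compound 4 (0.38 log units; beyond the scatter) and an at least 2.4-fold lower number from compound 1 to compound 4 (0.38 log units; beyond the scatter). The group on this nitrogen can therefore change the result, with the lower number standing for higher toxicity in this test, whereas the swaps among the smaller rings could not be read at all. Compound 4 is the only compound shown with a number, while compound 1, compound 2 and compound 3 each stand at a limit and not at a number, so each step gives only a minimum size: the limit of > 500000 nM in this assay, at which 3 of the 4 values shown sit.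

On these data alone, the true values of compound 1, compound 2 and compound 3 remain open, and with them the full size of each step and any order among those three compounds. Also open, as far as these compounds go, is whether the fall in the number needs the eight-membered ring itself, since cycloheptyl or an open octyl chain on the same nitrogen would be needed to separate the ring from its carbon count, and a hydroxyl or an amine on the cyclooctyl ring would test whether the change can be reversed.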